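The source may report more compounds than this note shows. Statements on the series, on what has been measured and on what is new or still open speak of the compounds shown alone.

Working notes on the series.

Compound 1 `COc1cc2c(Oc3ccc(NC(=O)c4cn(-c5ccc(Cl)cc5)cn4)cc3F)ccnc2cc1OCCCN1CCN(C)CC1` carries a 4-methylpiperazin-1-yl group on the propyl chain; in a functional assay on A549 cells (Homo sapiens) for cytotoxicity, read by MTT assay, with a stated time of 72 h (a lower number here means a stronger inhibitor, a higher number a weaker inhibitor), compound 1 gives 5200 nM. Compound 2 `COc1cc2c(Oc3ccc(NC(=O)c4cn(-c5ccc(Cl)cc5Cl)cn4)cc3F)ccnc2cc1OCCCN1CCN(C)CC1` differs by chloro in place of hydrogen on an aromatic carbon and in this assay compound 2 gives 3850 nM; the step is a 1.4-fold lower number from compound 1 to compound 2 (0.13 log units; within the scatter). Compound 3 `COc1cc2c(Oc3ccc(NC(=O)c4cn(-c5ccc(Cl)cc5)cn4)cc3F)ccnc2cc1OCCCN1CCCCC1` differs from compound 1 in the core, the difference being (piperidin-1-yl in place of 4-methylpiperazin-1-yl on a saturated chain carbon, three bonds along the chain from an oxygen on an aromatic ring); in this assay compound 3 gives 6560 nM, a step of a 1.3-fold higher number from compound 1 to compound 3 (0.10 log units; within the scatter). The three numbers sit close together, so no order among them can be claimed.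

Compound 4 `COc1cc2c(Oc3ccc(NC(=O)c4cn(-c5ccc(Cl)cc5Cl)cn4)cc3F)ccnc2cc1OCCCN1CCCCC1` has not been measured. It differs from compound 3 by chloro in place of hydrogen on an aromatic carbon, the same change that was made from compound 1 to compound 2, with the place described in identical words both times. For the measured compounds named here, only one measured instance exists, and it stayed within the scatter, so the expectation for compound 4 is a step of about a 1.4-fold lower number from compound 3 to compound 4 (0.14 log units; within the scatter), resting on the step of a 1.4-fold lower number from compound 1 to compound 2 (0.13 log units; within the scatter) and on compound 3 giving 6560 nM. Compound 4 is therefore estimated at 4800 nM, within 2500 nM to 9000 nM.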

Compound 4, half-maximal inhibitory concentration: 7490 nM
Beside the measured number, compound 4's estimate is 1.6-fold (0.19 log units) below it; the range from low to high includes it.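

In this assay, chloro in place of hydrogen gives a 1.1-fold higher number from compound 3 to compound 4 (0.06 log units; within the scatter), and set beside the earlier instance, this change carries from one core to the other with no gap that can be read: the same change on two cores in this assay, a 1.4-fold lower number (0.13 log units; within the scatter) from compound 1 to compound 2 and a 1.1-fold higher number (0.06 log units; within the scatter) from compound 3 to compound 4, 1.5-fold (0.19 log units) apart, within the scatter of two such steps

Piperidin-1-yl in place of 4-methylpiperazin-1-yl gives a 1.9-fold higher number from compound 2 to compound 4 (0.29 log units; within the scatter), and this change also reads alike on the two cores: the same change on two cores in this assay, a 1.3-fold higher number (0.10 log units; within the scatter) from compound 1 to compound 3 and a 1.9-fold higher number (0.29 log units; within the scatter) from compound 2 to compound 4, 1.5-fold (0.19 log units) apart, within the scatter of two such steps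

For the compounds shown here, with every step inside the scatter, this shows only that neither change gives a step beyond the scatter in these four compounds; it does not show that either change has a real effect of its own, or that the agreement would hold on any other core.

The compounds shown leave open whether any group on the 4-chlorophenyl or at the end of the propyl chain gives a step beyond the scatter in this assay. A nitrile in place of the added chloro, or a morpholin-4-yl in place of the piperidin-1-yl, would be a single-place comparison on the same cores.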